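Halogen swap at the ring carbon next to the nitrogen

The source may report more compounds than this note shows. Statements on the series, on what has been measured and on what is new or still open speak of the compounds shown alone.

For the measured compounds named here, compound 2 `Clc1ccc(C2=CC3CNCC(C2)C3)cn1` carries the lowest of the two numbers measured so far: in an in vitro functional assay on SH-EP1 cells for agonist activity at Neuronal acetylcholine receptor; alpha4/beta2 (Homo sapiens), read by FLIPR and calcium flux (on this read-out higher numbers stand for an effect only at larger amounts of compound and lower numbers for an effect already at smaller amounts), compound 2 gives 54 nM. Compound 1 `Clc1ccncc1C1=CC2CNCC(C1)C2` gives 2000 nM in this assay, and the gap between the two lies beyond the scatter. Compound 3 `Fc1ccc(C2=CC3CNCC(C2)C3)cn1`, not yet measured, differs from compound 2 in one place: fluoro in place of chloro on an aromatic carbon. Going by the values given here, no measured pair in this set shows such a halogen swap, so the size of the step in this assay cannot be read from the data. The working expectation is a small step toward a higher number, or none beyond the scatter. Compound 3 is estimated at 120 nM in this assay, with a range of 30 nM to 500 nM. This estimate means a step of a 2.2-fold higher number from compound 2 to compound 3 (0.35 log units; beyond the scatter), expected to stay near the scatter.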

Compound 3, half-maximal effective concentration: 85 nM
Estimate against measurement, compound 3: 1.4-fold (0.15 log units) above, and the stated range covers the measured number.
By their numbers in this assay, from the lowest: compounds 2 and 3 (each within the scatter of the next); then compound 1.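

In this assay, for the compounds shown here, the step of a 1.6-fold higher number from compound 2 to compound 3 (0.20 log units; within the scatter) gives the first reading of a halogen swap. On the aromatic carbon next to the ring nitrogen, fluoro in place of chloro leaves the number within the scatter, so at this position the read-out does not separate the two halogens. No supporting data bear on why the two halogens read alike.

Still open, from the compounds shown here alone, is whether this position accepts groups other than these two halogens, such as bromo, methoxy, an amine or a nitrile, or a bare ring hydrogen, with numbers in the same range. Also open, going by these compounds, is whether the same swap would read alike with the chloro of compound 1, which sits elsewhere on the ring.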